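The source may report more compounds than this note shows. Statements on the series, on what has been measured and on what is new or still open speak of the compounds shown alone.

Measured compounds:
Compound 1, `O=C(NCc1ccc(-c2noc(CCC3CC3)n2)cc1)[C@H]1NCC[C@@H]1O`: > 50 ug/mL
Compound 2, `CCCCCCCc1nc(-c2ccc([C@@H](NC(=O)[C@H]3NCC[C@@H]3O)C(C)C)cc2)no1`: 3 ug/mL

The study concerns solubility, read in a physicochemical assay for solubility, at pH 7.4; on this read-out lower numbers stand for lower solubility and higher numbers for higher solubility. Compound 1 does not give a number in this assay; its result is the limit of > 50 ug/mL in this assay, at which 1 of the 2 values shown sits, and nothing finer than that limit is known for it. Going by the values given here, compound 2 is therefore the only compound with an actual number in this assay, and that number is 3 ug/mL, which places compound 2 at the low end of what this assay shows.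

The step under consideration leads from compound 2 to compound 3, `CCCCCCCc1nc(-c2ccc([C@H](C)NC(=O)[C@H]3NCC[C@@H]3O)cc2)no1`, which has not yet been measured. The change is methyl in place of isopropyl on a saturated chain carbon bound to an amide-type nitrogen and an aromatic carbon. Among the compounds with values here, compound 1 and compound 2 differ in more than one place, so no step between them is given and their two values are taken only as they stand.

The writer estimates this step as a 2.3-fold higher number from compound 2 to compound 3 (0.37 log units; beyond the scatter), an expected small to moderate move toward higher solubility. Compound 3 is accordingly estimated at 7 ug/mL, in the range from 2.5 ug/mL to 20 ug/mL.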

Compound 3, solubility: 27 ug/mL
The estimate for compound 3 lay 3.9-fold (0.59 log units) below the measured number, and the stated range ends below it.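

Putting methyl in place of isopropyl on a saturated chain carbon bound to an amide-type nitrogen and an aromatic carbon gives, in this assay, a 9.0-fold higher number from compound 2 to compound 3 (0.95 log units; beyond the scatter), a step beyond the scatter and the first that can be read at this position. The earlier compounds shown here offered no such step, and this one shows that the read-out is not indifferent to the group on this carbon, even though the two groups are alike in carrying no ring, no hydrogen-bond donors, no hydrogen-bond acceptors and no net charge, and differ in heavy atoms, 3 against 1. Nothing given here bears on the cause of this step.

From the compounds shown here alone, what an ethyl group, a longer chain or an amine on this same carbon would give remains open, as does whether the step would keep its size with a different chain on the shared core. Compound 1 differs from compound 2 and compound 3 in more than one place and offers no comparison, and its result is a limit and not a number: the limit of > 50 ug/mL in this assay, at which 1 of the 3 values shown sits.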